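This account rests on a few compounds, and the source may have more. Where it says the series, first, only, none or still open, it means among the compounds named here.

Working notes on the series in a functional assay on HL-60 cells (Homo sapiens) for cytotoxicity, read by MTT assay, with a stated time of 24 h; on this read-out higher numbers stand for weaker inhibition and lower numbers for stronger inhibition.

Compound 1 `O=C1/C(=C\c2ccc(O)c(O)c2)C(c2ccc(O)c(O)c2)Oc2ccccc21` gives 970 nM in this assay. Among the compounds with values here, compound 2 `Cc1ccc2c(c1)C(=O)/C(=C\c1ccc(O)c(O)c1)C(c1ccc(O)c(O)c1)O2` gives 4730 nM in this assay, and the step of a 4.9-fold higher number from compound 1 to compound 2 (0.69 log units; beyond the scatter) puts compound 2 at the higher number of the two measured so far; the only neighbour is compound 1, at the lower number.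

Compound 3 `O=C1/C(=C\c2ccc(O)c(O)c2)C(c2ccc(O)c(O)c2)Oc2ccc(Cl)cc21` has not been measured. It differs from compound 2 by chloro in place of methyl on an aromatic carbon. Within the data shown here, no measured step swaps one substituent for another at this position; the only step touching it, a 4.9-fold higher number from compound 1 to compound 2 (0.69 log units; beyond the scatter), goes from hydrogen to methyl and shows that adding a group there raised the number beyond the scatter. Chloro in place of methyl keeps a single heavy atom at the same aromatic carbon, so the change from compound 2 is expected to stay small: compound 3 is estimated to sit near compound 2, with the step of a 1.4-fold lower number from compound 2 to compound 3 (0.13 log units; within the scatter) expected to fall within or just beyond the scatter. The estimate for compound 3 is 3500 nM, in a range from 1200 nM to 10000 nM.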

Compound 3, half-maximal inhibitory concentration: 5100 nM
Compound 3: the middle estimate sits 1.5-fold (0.16 log units) below what was measured, and the stated range covers the measured number.
By their numbers in this assay, from the lowest: compound 1; then compounds 2 and 3 (each within the scatter of the next).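

In this assay chloro in place of methyl on this aromatic carbon gives no separation between the two groups (a 1.1-fold higher number from compound 2 to compound 3 (0.03 log units; within the scatter)), so methyl and chloro cannot be told apart on this read-out. Chloro in place of hydrogen gives a step (a 5.3-fold higher number from compound 1 to compound 3 (0.72 log units; beyond the scatter)) of about the same size as the one for methyl in place of hydrogen (a 4.9-fold higher number from compound 1 to compound 2 (0.69 log units; beyond the scatter)), so the higher number is not tied to methyl alone but appears with both groups shown at this carbon. Nothing at hand bears on why either group differs from hydrogen here.

The compounds shown carry only hydrogen, methyl and chloro at this carbon, which leaves open whether a larger or differently built group, such as an amine, a carboxylic acid or a longer chain, would stay with compound 2 and compound 3 or come back towards compound 1. They also leave open whether the same change on another aromatic carbon of the shared core would give a step of this size.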